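Moving the ring nitrogen on the pyrazole substituent

This account rests on a few compounds, and the source may have more. Where it says the series, first, only, none or still open, it means among the compounds named here.

Compound 3 `COc1ccc(C(=O)/C=C/c2cn(-c3ccccc3)nc2-c2cccnc2)cc1OC` was tested in a functional assay on MCF7 cells (Homo sapiens) for inhibition, read by sulforhodamine B assay, with a stated time of 72 h (a higher number here means a weaker inhibitor, a lower number a stronger inhibitor), and gives 1700 nM. Among the three compounds measured in this assay it holds the second highest number. Its nearest neighbour is compound 2 `COc1ccc(C(=O)/C=C/c2cn(-c3ccccc3)nc2-c2cccnc2)c(OC)c1OC`, which gives 1400 nM; the step of a 1.2-fold higher number from compound 2 to compound 3 (0.08 log units; within the scatter) lies within the scatter, so the two cannot be told apart. Compound 1 `O=C(/C=C/c1cn(-c2ccccc2)nc1-c1cccnc1)c1ccccn1` gives 4200 nM, and the step of a 2.5-fold lower number from compound 1 to compound 3 (0.39 log units; beyond the scatter) is a modest gain that does lie beyond the scatter.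

Compound 4 `COc1ccc(C(=O)/C=C/c2cn(-c3ccccc3)nc2-c2ccncc2)cc1OC` differs from compound 3 only in one place: pyridin-4-yl in place of pyridin-3-yl on an aromatic carbon. Within the data shown here, both measured steps changed the group on the carbonyl carbon or a methoxy on that aryl ring; neither touched the pyridyl group on the five-membered ring, so no measured step bears directly on this change. Among the measured compounds shown here, with no precedent in these data, a step of no more than the usual scatter is expected, with no direction favoured, which is what no change at the digits printed from compound 3 to compound 4 (within the scatter) expresses. Compound 4 is therefore estimated at 1700 nM in this assay, with a range from 800 nM to 3600 nM.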

Compound 4, half-maximal inhibitory concentration: 4300 nM
Estimate against measurement, compound 4: 2.5-fold (0.40 log units) below; the measured number lies above the stated range.
By their numbers in this assay, from the lowest: compounds 2 and 3 (each within the scatter of the next); then compounds 1 and 4 (each within the scatter of the next).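

Among these compounds, this is the first change at the pyridyl group on the five-membered aromatic ring, and it shows that this position is sensitive in this assay: pyridin-4-yl in place of pyridin-3-yl gives a 2.5-fold higher number from compound 3 to compound 4 (0.40 log units; beyond the scatter). The two groups have the same atoms and the same counts of donors and acceptors, so joining those atoms differently is enough to produce a step beyond the scatter, even though the whole group on the carbonyl carbon was exchanged in the earlier step, a 2.5-fold lower number from compound 1 to compound 3 (0.39 log units; beyond the scatter). Nothing available here explains why this rearrangement weakens inhibition.

The compounds shown leave open whether a plain phenyl or a pyridin-2-yl group at this position would give a number closer to that of compound 3 or compound 4, and what an amine or a methoxy on the pyridine ring would do. They also leave open whether the same step would appear with pyridin-2-yl or the trimethoxyphenyl group of compound 2 on the carbonyl carbon.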